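Extending the Chain: From Compound 3 to Compound 4

A few compounds are considered here, and "the series" means these few. Any claim that something is new, unique, unknown or untested is made for them only; others in the source may bear on it.

Compound 1, `CN1CCN(c2nc3ccccc3n2CCO)CC1`, gives 410 nM in a functional assay on ileum for inhibition of histamine H1 receptor (Cavia porcellus); on this read-out lower numbers stand for stronger inhibition and higher numbers for weaker inhibition.
Compound 2, `COCCCn1c(N2CCN(C)CC2)nc2ccccc21`, gives 860 nM in this assay.
Compound 3, `CCCCCCCn1c(N2CCN(C)CC2)nc2ccccc21`, gives 150 nM in this assay.

Three compounds share one core and differ only in the chain carried on the aromatic nitrogen. Compound 3 stands lowest of the three numbers: its nearest neighbour is compound 1, at a step of a 2.7-fold lower number from compound 1 to compound 3 (0.44 log units; beyond the scatter), and its furthest is compound 2, at a 5.7-fold lower number from compound 2 to compound 3 (0.76 log units; beyond the scatter). Both of these steps move toward compound 3 by replacing an oxygen-bearing group with a plain carbon chain, and both lower the number beyond the scatter.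

Compound 4, `CCCCCCCCCCn1c(N2CCN(C)CC2)nc2ccccc21`, is the next compound, differing from compound 3 by propyl in place of hydrogen on a saturated chain carbon, seven bonds along the chain from an aromatic nitrogen. This continues the same direction of change, a longer chain without oxygen. Among the measured compounds shown here, the two steps that bear on it were each modest, and no measured pair tests a change in chain length alone, so the expected step is smaller. Compound 4 is estimated to give 110 nM (range 45 nM to 270 nM), a step of a 1.4-fold lower number from compound 3 to compound 4 (0.13 log units; within the scatter) that is expected to stay near the scatter.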

Compound 4, half-maximal inhibitory concentration: 4200 nM
Compound 4: middle estimate off by 38-fold (1.58 log units), on the low side; measured number outside the range, above it.
By their numbers in this assay, from the lowest: compound 3; then compound 1; then compound 2; then compound 4.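

Lengthening the chain does not bring a steady gain in this assay: propyl in place of hydrogen, seven bonds along the chain from an aromatic nitrogen, gives a 28-fold higher number from compound 3 to compound 4 (1.45 log units; beyond the scatter), so this position tolerates the shorter carbon chain far better than the longer one. The longer chain also falls behind both oxygen-bearing chains, with a 4.9-fold higher number from compound 2 to compound 4 (0.69 log units; beyond the scatter) and a 10-fold higher number from compound 1 to compound 4 (1.01 log units; beyond the scatter), which shows that removing oxygen from the chain does not by itself secure a lower number. Nothing available here accounts for this reversal.

The compounds shown leave open where the number begins to climb, for instance with methyl or ethyl in place of that same hydrogen. They also leave open whether a long chain ending in an amine or a carboxylic acid would behave like compound 4.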